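Moving the hydroxymethyl group around the outer ring

The source may report more compounds than this note shows. Statements on the series, on what has been measured and on what is new or still open speak of the compounds shown alone.

The shared core of these three compounds carries a side chain ending in a carboxylic acid, a seven-membered nitrogen ring, and a biphenyl-like tail that differs only in its last substituent. In a functional assay for antagonist activity at thromboxane A2 receptor (Rattus norvegicus) (on this read-out lower numbers stand for tighter binding and higher numbers for weaker binding), compound 1 `CC(=O)NCc1ccccc1-c1ccc(COC2CC[C@H](N3CCCCCC3)[C@H]2OC/C=C\CCC(=O)O)cc1` gives 126 nM. Compound 2 `CC(=O)NCc1ccc(-c2ccc(COC3CC[C@H](N4CCCCCC4)[C@H]3OC/C=C\CCC(=O)O)cc2)cc1` gives 20 nM, and compound 3 `O=C(O)CC/C=C\CO[C@H]1C(OCc2ccc(-c3ccc(CO)cc3)cc2)CC[C@@H]1N1CCCCCC1` gives 20 nM; compound 3 stands level with compound 2, and the two together give the lowest numbers of the three.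

Compound 4 `O=C(O)CC/C=C\CO[C@H]1C(OCc2ccc(-c3ccccc3CO)cc2)CC[C@@H]1N1CCCCCC1` differs from compound 3 in one place: 2-(hydroxymethyl)phenyl in place of 4-(hydroxymethyl)phenyl on an aromatic carbon. Within the data shown here, the only measured step that bears on this is the reverse of it with an acetamidomethyl group instead, where a 6.3-fold lower number from compound 1 to compound 2 (0.80 log units; beyond the scatter). Going back the other way, a rise in this assay of a similar size is expected, that is a 6.0-fold higher number from compound 3 to compound 4 (0.78 log units; beyond the scatter). Compound 4 is therefore estimated at 120 nM in this assay, with a plausible range from 40 nM to 360 nM.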

Compound 4, dissociation constant: 6.31 nM
Compound 4: the middle estimate sits 19-fold (1.28 log units) above what was measured, outside the stated range (below it).
By their numbers in this assay, from the lowest: compound 4; then compounds 2 and 3 (each within the scatter of the next); then compound 1.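

In this assay, moving the group from the 4-(hydroxymethyl)phenyl to the 2-(hydroxymethyl)phenyl arrangement gives a 3.2-fold lower number from compound 3 to compound 4 (0.50 log units; beyond the scatter), whereas the acetamidomethyl pair runs the opposite way, with a 6.3-fold lower number from compound 1 to compound 2 (0.80 log units; beyond the scatter) on going from the 2-substituted to the 4-substituted ring. The 2-(hydroxymethyl)phenyl tail also improves on the 4-(acetamidomethyl)phenyl tail, with a 3.2-fold lower number from compound 2 to compound 4 (0.50 log units; beyond the scatter). Hydroxy in place of acetamido gives a 20-fold lower number from compound 1 to compound 4 (1.30 log units; beyond the scatter) on the 2-substituted ring but nothing comparable on the 4-substituted ring, so the effect of this exchange depends on where the group sits: the same change on two cores in this assay, no change at the digits printed (within the scatter) from compound 2 to compound 3 and a 20-fold lower number (1.30 log units; beyond the scatter) from compound 1 to compound 4, 20-fold (1.30 log units) apart, beyond the scatter of two such steps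

The compounds shown leave open whether the low number of compound 4 is specific to the hydroxy group or would hold for an amine or a carboxylic acid in its place. They also cannot tell why the two groups respond to the move in opposite directions.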